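Trifluoromethyl for fluoro on the weakly active compound 2

A few compounds are considered here, and "the series" means these few. Any claim that something is new, unique, unknown or untested is made for them only; others in the source may bear on it.

Compound 2 `Oc1cccc(-c2cc(-c3cccc(F)c3)cc(-c3ccccc3O)n2)c1` gives > 50000 nM in a functional assay on DU-145 cells (Homo sapiens) for inhibition (on this read-out higher numbers stand for weaker inhibition and lower numbers for stronger inhibition), a limit of the assay rather than a number. Compound 1 `Oc1ccccc1-c1cc(-c2cccc(F)c2)cc(-c2ccccc2O)n1` also returns only a limit, > 50000 nM. Compound 3 `Oc1ccc(-c2cc(-c3cccc(F)c3)cc(-c3cccc(O)c3)n2)cc1` gives 2700 nM in this assay. The step that the two limits leave unreadable from compound 1 to compound 2 stays unreadable, whereas the step of an at least 18-fold lower number from compound 2 to compound 3 (1.26 log units; beyond the scatter) is large. Compound 4 `Oc1cccc(-c2cc(-c3cccc(C(F)(F)F)c3)cc(-c3ccccc3O)n2)c1` differs from compound 2 by trifluoromethyl in place of fluoro on an aromatic carbon. Neither measured step touches this group; both exchange one hydroxyphenyl for another, and two of the three values sit at the limit (the limit of > 50000 nM in this assay, at which 2 of the 3 values shown sit). Among the compounds with values here, no measured step therefore bears on this change, and the expected step of a number no higher from compound 2 to compound 4 (the limit leaves the size open) is small. Compound 4 is expected near 50000 nM, between 10000 nM and 200000 nM, most likely again reported as a limit.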

Compound 4, half-maximal inhibitory concentration: 13000 nM
For compound 4 the middle estimate is 3.8-fold (0.59 log units) above the measured one; the measured number falls inside the stated range.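

In this assay, within the data shown here, the exchange of 3-fluorophenyl for 3-(trifluoromethyl)phenyl gives an at least 3.8-fold lower number from compound 2 to compound 4 (0.58 log units; beyond the scatter), so this position, untouched by the earlier steps, does affect the read-out. Compound 4 gives a measured number with a 2-hydroxyphenyl group still in place, which compound 2 does not. The full size of the step stays unreadable, as its starting value is a limit: the limit of > 50000 nM in this assay, at which 2 of the 4 values shown sit.

On these data alone, whether trifluoromethyl brings a similar step on the hydroxyphenyl pattern of compound 3 remains open. So does how an amine or a carboxylic acid at this position would read.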